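Isopropyl in Place of Methoxyethyl on the Sulfonamide

A few compounds are considered here, and "the series" means these few. Any claim that something is new, unique, unknown or untested is made for them only; others in the source may bear on it.

Of the compounds shown here, two sharing one core have been measured in a functional assay on cells for antagonist activity at prostaglandin D2 receptor 2 (Homo sapiens), read by flow cytometry, with a stated time of 10 min; on this read-out higher numbers stand for weaker inhibition and lower numbers for stronger inhibition. Among the compounds with values here, compound 2 `COCCNS(=O)(=O)c1ccc(C)c(C#Cc2cc(Cl)ccc2OCC(=O)O)c1` gives 88 nM, and compound 1 `COCCN(C)S(=O)(=O)c1ccc(C)c(C#Cc2cc(Cl)ccc2OCC(=O)O)c1` gives 77 nM; the one step between them, a 1.1-fold higher number from compound 1 to compound 2 (0.06 log units; within the scatter), alters the sulfonamide nitrogen and stays within the scatter. Compound 3 `Cc1ccc(S(=O)(=O)NC(C)C)cc1C#Cc1cc(Cl)ccc1OCC(=O)O` differs from compound 2 by isopropyl in place of 2-methoxyethyl on a sulfonamide nitrogen, at that same nitrogen. No step beyond the scatter is expected in this assay, because a 1.1-fold higher number from compound 1 to compound 2 (0.06 log units; within the scatter) at this nitrogen stayed within it. Compound 3 is therefore estimated at 90 nM, within 35 nM to 230 nM. The expected step is a 1.0-fold higher number from compound 2 to compound 3 (0.01 log units; within the scatter).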

Compound 3, half-maximal inhibitory concentration: 250 nM
Compound 3: the middle estimate sits 2.8-fold (0.44 log units) below what was measured; the measured number lies above the stated range.
By their numbers in this assay, from the lowest: compounds 1 and 2 (each within the scatter of the next); then compound 3.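

In this assay the sulfonamide nitrogen proves sensitive to the chain it carries, although losing the methyl alone had stayed within the scatter: isopropyl in place of 2-methoxyethyl gives a modest change (a 2.8-fold higher number from compound 2 to compound 3 (0.45 log units; beyond the scatter)). Isopropylamino in place of (2-methoxyethyl)(methyl)amino on the sulfonyl sulfur gives a similar modest change (a 3.2-fold higher number from compound 1 to compound 3 (0.51 log units; beyond the scatter)). No measurement shown bears on the reason for these steps. Still open, from the compounds shown here alone, is whether a longer chain such as 3-methoxypropyl, or a chain ending in an amine, would read like compound 2 or compound 3. Also open, going by these compounds, is whether a methyl on the nitrogen of compound 3 would shift its number.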